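Trimethoxyphenyl pyrazole enones: swapping the aryl ketone substituent

This account rests on a few compounds, and the source may have more. Where it says the series, first, only, none or still open, it means among the compounds named here.

Compound 1, `COc1cc(-c2cc(/C=C/C(=O)c3ccc(N)cc3)[nH]n2)cc(OC)c1OC`, belongs to a small set of pyrazole-linked enones sharing a trimethoxyphenyl group on the core. In a functional assay on HT-29 cells (Homo sapiens) for inhibition, read by sulforhodamine B assay, with a stated time of 48 h (a lower number here means a stronger inhibitor of growth, a higher number a weaker inhibitor of growth), compound 1 gives 1850 nM, the higher of the two numbers measured, though its nearest neighbour, compound 2, `COc1ccc(-c2cc(/C=C/C(=O)c3ccc(OC)c(OC)c3)[nH]n2)cc1`, sits within the scatter of it with 1550 nM in this assay. Within the data shown here, the two measured compounds differ in more than one place, so no single step between them can be read off; their numbers simply show that both lie in the same range.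

Compound 3, `COc1cc(-c2cc(/C=C/C(=O)c3ccc(Cl)c(Cl)c3)[nH]n2)cc(OC)c1OC`, differs from compound 1 in one place: 3,4-dichlorophenyl in place of 4-aminophenyl on a carbonyl carbon. Among the measured compounds shown here, no measured pair in the set isolates a change of this kind, so there is no direct precedent for its size. The step from compound 1 to compound 3 in this assay is expected to be modest, a 1.5-fold lower number from compound 1 to compound 3 (0.19 log units; within the scatter), most likely toward a somewhat lower number but possibly not beyond the scatter. On that basis compound 3 is estimated at 1200 nM in this assay, with a plausible range from 400 nM to 4000 nM.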

Compound 3, concentration for 50% growth inhibition: 1150 nM
For compound 3 the middle estimate is 1.0-fold (0.02 log units) above the measured one, and the stated range covers the measured number.
By their numbers in this assay, from the lowest: compounds 3, 2 and 1 (each within the scatter of the next).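

In this assay, among these compounds, the exchange of 3,4-dichlorophenyl for 4-aminophenyl on a carbonyl carbon gives a 1.6-fold lower number from compound 1 to compound 3 (0.21 log units; within the scatter) and is the first change in the set that can be read at a single place. It shows that, with the rest of compound 1 held fixed, this position accepts a group with no hydrogen-bond donor or acceptor in place of one that has both, and the number stays within the scatter. Nothing measured here accounts for this result.

One pair cannot show how far this position can be pushed: a 4-hydroxyphenyl, a 4-carboxyphenyl or a pyridine ring on the same carbonyl carbon might give a step beyond the scatter, or might not. On these data alone, compound 2 differs from both of the others in more than one place, so its steps cannot be read, and whether the same exchange would give a similar step on its core remains open.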